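Sulfonyl chain amines and solubility in the series

The compounds below may be only part of what the source reports. "The series", "measured", "known", "first", "only" and "open" are said of these compounds alone.

Compound 2 `CS(=O)(=O)c1ccc2nc(NC(=O)NC(=O)c3ccccc3Cl)sc2c1` carries a bare methylsulfonyl group. In a physicochemical assay for solubility, at pH 7.4 (a higher number here means a more soluble compound, a lower number a less soluble compound), compound 2 gives only a limit, < 470 nM, and not a number. Compound 1 `CN1CCN(CCCS(=O)(=O)c2ccc3nc(NC(=O)NC(=O)c4ccccc4Cl)sc3c2)CC1` carries a basic chain on the sulfonyl group; in this assay compound 1 gives 280000 nM. Going by the values given here, the one measured step runs the other way: an at least 590-fold lower number from compound 1 to compound 2 (2.77 log units; beyond the scatter). Compound 2 sits at the floor of the measurements, (the limit of < 470 nM in this assay, at which 1 of the 2 values shown sits), so any rise from it can only be read against compound 1. Compound 3 `CCN(CC)CCCS(=O)(=O)c1ccc2nc(NC(=O)NC(=O)c3ccccc3Cl)sc2c1` is not yet measured and differs from compound 2 by 2-(diethylamino)ethyl in place of hydrogen on a saturated chain carbon bound to a sulfonyl sulfur. The change mirrors the measured step in reverse, so a large rise is expected, an at least 210-fold higher number from compound 2 to compound 3 (2.32 log units; beyond the scatter), because compound 1 in this assay gives 280000 nM. The estimate for compound 3 in this assay is 100000 nM, ranging from 15000 nM to 400000 nM.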

Compound 3, solubility: 280000 nM
Estimate against measurement, compound 3: 2.8-fold (0.45 log units) below; the measured number falls inside the stated range.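

In this assay, the second chain repeats the large gain seen with compound 1, now with 2-(diethylamino)ethyl on a saturated chain carbon bound to a sulfonyl sulfur: an at least 590-fold higher number from compound 2 to compound 3 (2.77 log units; beyond the scatter). The gain therefore no longer rests on one chain, and the choice between the two terminal groups, diethylamino without a ring and 4-methylpiperazin-1-yl with one, does not separate the pair: no change at the digits printed from compound 1 to compound 3 (within the scatter). The first step gives only a minimum size, since compound 2 stands at a limit and not at a number: the limit of < 470 nM in this assay, at which 1 of the 3 values shown sits.

The compounds shown do not separate the contribution of the chain itself from that of its nitrogen, which a plain propyl chain or a chain carrying a hydroxyl group would address. Also open, on these data alone, are a morpholine terminal group, a carboxylic acid on the chain, and shorter or longer chains.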